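A few compounds are considered here, and "the series" means these few. Any claim that something is new, unique, unknown or untested is made for them only; others in the source may bear on it.

Working notes on the series. Two compounds have numbers in an assay on brain (strain C57BL6) for displacement of a labelled ligand from AP2-associated protein kinase 1 (Mus musculus), read by scintillation counting, with a stated time of 1 h; a lower number here means a stronger inhibitor, a higher number a weaker inhibitor. Compound 1 `COC(=O)Nc1cc(-c2ccc(OC[C@@](C)(N)CC(C)C)cn2)ccn1` gives 18 nM in this assay, which is the higher of the two numbers. Its nearest neighbour is compound 2 `COC(=O)Nc1cc(-c2ccc(OC[C@@](C)(N)CC(C)C)nc2)ccn1`, and compound 2 gives 4.9 nM in this assay, a gap that lies beyond the scatter. For the measured compounds named here, no single-site step between measured compounds is available, so the size of an added substituent's effect is not known from data in this set.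

Compound 3 `COC(=O)Nc1cc(-c2ccc(OC[C@@](C)(N)CC(C)C)c(Cl)n2)ccn1` differs from compound 1 by chloro in place of hydrogen on an aromatic carbon, on an aromatic carbon of a six-membered aromatic ring with one nitrogen, next to the ring nitrogen and ortho to the (2-amino-2,4-dimethylpentyl)oxy group. Going by the values given here, with no comparable step on record, the expectation is for at most a small step, a 1.1-fold higher number from compound 1 to compound 3 (0.05 log units; within the scatter), not clearly beyond the scatter. Compound 3 is estimated at 20 nM in this assay, with a range of 6 nM to 70 nM.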

Compound 3, inhibition constant: 0.17 nM
The estimate for compound 3 lay 120-fold (2.07 log units) above the measured number, and the stated range ends above it.
By their numbers in this assay, from the lowest: compound 3; then compound 2; then compound 1.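

In this assay, for the compounds shown here, chloro in place of hydrogen on an aromatic carbon, next to the ring nitrogen and ortho to the (2-amino-2,4-dimethylpentyl)oxy group, gives a 110-fold lower number from compound 1 to compound 3 (2.02 log units; beyond the scatter), the first single-site step and a large one. The change enters only 1 heavy atom, with no hydrogen-bond donor or acceptor and no net charge, so the number in this series can respond strongly to a minimal change at this position. Nothing on record bears on the origin of this step.

On these data alone, whether the step is particular to chloro remains open, since fluoro, bromo, methyl or nitrile at the same position would be needed to show this. As far as these compounds go, it is also open whether chloro would give a comparable step on the core of compound 2.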